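The compounds below may be only part of what the source reports. "The series", "measured", "known", "first", "only" and "open" are said of these compounds alone.

In a functional assay on CUTLL1 cells (Homo sapiens) for inhibition, read by resazurin assay, with a stated time of 48 h, in the absence of a further agent (a lower number here means that less compound is needed, a higher number that more compound is needed for the effect), compound 3 (`CC(C)c1nc(N)ncc1-c1ccncc1`) gives > 100000 nM, which is a limit of the assay and not a number. Compound 1 (`Nc1ncc(-c2ccccc2)c(C2CC2)n1`) also gives only a limit, > 100000 nM. Compound 2 (`Nc1ncc(-c2ccc(F)cc2)c(C2CC2)n1`) likewise gives only a limit, > 100000 nM. The series thus stands at the limit of > 100000 nM in this assay, at which 3 of the 3 values shown sit. Compared with compound 3, compound 4 (`Nc1ncc(-c2ccncc2)c(C2CCC2)n1`) carries cyclobutyl in place of isopropyl on an aromatic carbon. For the measured compounds named here, the only measured step, a step that the two limits leave unreadable from compound 1 to compound 2, concerns a different change and sets no size, so no step beyond the scatter is expected in this assay. The estimated step is a number no higher from compound 3 to compound 4 (the limit leaves the size open). The expected value for compound 4 is 100000 nM, with an estimated range of 40000 nM to 200000 nM.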

Compound 4, half-maximal effective concentration: > 100000 nM
Compound 4: only a limit was reported; the forecaster's own chance of this, stated with the estimate: 85%; the middle value sits exactly at the limit.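

Compound 3 and compound 4 are both reported only as limits, so the step between them cannot be read. In this assay the compounds shown leave open whether any change on the shared core would give a readable value, as the series stands at one limit: the limit of > 100000 nM in this assay, at which 4 of the 4 values shown sit.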